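The source may hold more compounds than are shown below. What is called first, only, known or untested is meant among the compounds shown, and "the series" means these compounds.

Compound 1 `COc1cc(-c2nn(-c3cccc(NC(=O)Nc4cc(C(F)(F)F)cc(C(F)(F)F)c4)c3)cc2-c2ccncc2)ccc1Cl`: in a functional assay on OVCAR-4 cells (Homo sapiens) for inhibition, read by sulforhodamine B assay, with a stated time of 48 h (a lower number here means that less compound is tolerated, a higher number that more compound is tolerated), compound 1 reaches only the assay limit, > 50000 nM.
Compound 2 `O=C(Nc1cccc(-n2cc(-c3ccncc3)c(-c3ccc(Cl)c(O)c3)n2)c1)Nc1cc(C(F)(F)F)cc(C(F)(F)F)c1`: in this assay compound 2 gives 23900 nM.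
Compound 3 `COc1cc(-c2nn(-c3cccc(NC(=O)Nc4ccc(Cl)c(C(F)(F)F)c4)c3)cc2-c2ccncc2)ccc1Cl`: in this assay compound 3 reaches only the assay limit, > 32500 nM.

Compound 1 and compound 2 differ in one place: hydrogen in place of methyl on an oxygen on an aromatic ring. That change produced an at least 2.0-fold lower number from compound 1 to compound 2 (0.32 log units; beyond the scatter). The cores of compound 1 and compound 3 also differ, but that difference is not broken down here. Compound 4 `O=C(Nc1cccc(-n2cc(-c3ccncc3)c(-c3ccc(Cl)c(O)c3)n2)c1)Nc1ccc(Cl)c(C(F)(F)F)c1` has not yet been measured; it stands to compound 3 as compound 2 stands to compound 1, carrying the same change at the same place: hydrogen in place of methyl on an oxygen on an aromatic ring. The starting point for compound 3 is a limit, > 32500 nM, so a number for compound 4 can only be guessed. A step of about an at least 1.6-fold lower number from compound 3 to compound 4 (0.21 log units; that floor lies within the scatter) is expected. This expectation rests on an at least 2.0-fold lower number from compound 1 to compound 2 (0.32 log units; beyond the scatter). Compound 4 is therefore expected to give roughly 20000 nM, somewhere between 8000 nM and 50000 nM.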

Compound 4, concentration lethal to 50% of the cells: > 32500 nM
Compound 4: no number, only a limit (the forecaster's own chance of this, stated with the estimate: 30%); middle value at least 1.6-fold (0.21 log units) from the limit.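

Compound 3 and compound 4 both reach only an assay limit, so no step between them can be read: the limit of > 32500 nM in this assay, at which 2 of the 4 values shown sit.

The compounds shown leave open whether methoxy to hydroxy lowers the number on the core of compound 3, as it does from compound 1 to compound 2.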